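The source may report more compounds than this note shows. Statements on the series, on what has been measured and on what is new or still open speak of the compounds shown alone.

Compound 2 `CC(C)c1ccc(/C(=C\CC(N)C(=O)O)c2ccccc2F)cc1` gives 8020 nM in a functional assay for inhibition of sodium- and chloride-dependent glycine transporter 1 (Rattus norvegicus), with a stated time of 30 min, in the presence of a further agent that is not named here; a higher number here means a weaker inhibitor, a lower number a stronger inhibitor. Within the data shown here, of the two numbers measured so far it carries the smaller, though the gap to compound 1 `CC(C)c1ccc(/C(=C\CC(N)C(=O)O)c2ccccc2)cc1`, which gives 8340 nM, lies within the scatter. Among the measured compounds shown here, the single measured step, a 1.0-fold lower number from compound 1 to compound 2 (0.02 log units; within the scatter), is a change on the same ring but of a different kind. Compound 3 `CC(C)c1ccc(/C(=C\CC(N)C(=O)O)c2ccc(C#N)cc2)cc1` differs from compound 2 by 4-cyanophenyl in place of 2-fluorophenyl on a double-bonded chain carbon bound to an aromatic carbon and a double-bonded chain carbon. For the measured compounds named here, no measured step covers a nitrile; the one ring change seen moved nothing. For compound 3 the estimate is 9000 nM, with range 3000 nM to 27000 nM. This means an expected step of a 1.1-fold higher number from compound 2 to compound 3 (0.05 log units; within the scatter), not beyond the scatter.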

Compound 3, half-maximal inhibitory concentration: > 10000 nM
Compound 3: no number, only a limit (the forecaster's own chance of this, stated with the estimate: 10%); middle value at least 1.1-fold (0.04 log units) from the limit.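

For compound 3 the reading is only a limit, > 10000 nM. This gives floors rather than sizes: an at least 1.2-fold higher number from compound 2 to compound 3 (0.09 log units; that floor lies within the scatter), and an at least 1.1-fold higher number from compound 1 to compound 3 (0.07 log units; that floor lies within the scatter). The nitrile at this position therefore brings no sign of stronger inhibition, but it is not shown to weaken inhibition either, and the true size of either step remains unread. On these data alone, whether any change on this ring can move the number beyond the scatter stays open. So does the outcome with an amine or a methoxy group in place of the nitrile.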